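Amide variation on the shared core: compound 3 to compound 4

The compounds below may be only part of what the source reports. "The series", "measured", "known", "first", "only" and "open" are said of these compounds alone.

The series is read in a functional assay on PC-3 cells (Homo sapiens) for inhibition, read by MTT assay, with a stated time of 48 h; on this read-out lower numbers stand for stronger inhibition and higher numbers for weaker inhibition. Compound 1 `CCn1c(/C=C2\SC(=O)N(CC(=O)N3CCCCC3)C2=O)nc2ccccc21` returns only the limit of this assay, > 50000 nM, a limit and not a number. Compound 2 `CC(C)n1c(/C=C2\SC(=O)N(CC(=O)N3CCOCC3)C2=O)nc2ccccc21` likewise returns only the limit > 50000 nM. Compound 3 `CCn1c(/C=C2\SC(=O)N(CC(=O)N3CC(C)OC(C)C3)C2=O)nc2ccccc21` also gives only the limit > 50000 nM. Every measured value in the set thus sits on (the limit of > 50000 nM in this assay, at which 3 of the 3 values shown sit), and compound 3 cannot be placed relative to its neighbours beyond that.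

Compound 4 `CCn1c(/C=C2\SC(=O)N(CC(=O)N3CCOCC3)C2=O)nc2ccccc21` differs from compound 3 by morpholin-4-yl in place of 2,6-dimethylmorpholin-4-yl on a carbonyl carbon. Among the measured compounds shown here, the one measured step at the same place, a step that the two limits leave unreadable from compound 1 to compound 3, is left unreadable by the two limits, so no size or direction in this assay is available from it. Compound 4 is expected to remain at the limit as well. The expected step is a step that the limit leaves unreadable from compound 3 to compound 4, no change that could be read. The estimate for compound 4 is 100000 nM, within a range of 50000 nM to 300000 nM, with another limit the likeliest outcome.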

Compound 4, half-maximal inhibitory concentration: > 50000 nM
Compound 4 gave a limit, no number (the forecaster's own chance of this, stated with the estimate: 85%); the middle value is on the limit's open side.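

No step can be read among compound 1, compound 2, compound 3 and compound 4 in this assay, since each gives only a limit: the limit of > 50000 nM in this assay, at which 4 of the 4 values shown sit.

The compounds shown leave open which change on the shared core, if any, would bring a readable value in this assay.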